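From 3-Fluorophenyl to 2-Hydroxyphenyl: An Estimate for Compound 3

The source may report more compounds than this note shows. Statements on the series, on what has been measured and on what is new or still open speak of the compounds shown alone.

Compound 1 `CC(=O)N1N=C(c2ccc3ccccc3c2)OC1c1ccccc1Br` gives 6.98 ug/mL
Compound 2 `CC(=O)N1N=C(c2ccc3ccccc3c2)OC1c1cccc(F)c1` gives 1.61 ug/mL

In a functional assay on B16-F10 cells (Mus musculus) for antiproliferative activity, read by MTT assay, with a stated time of 48 h (on this read-out higher numbers stand for weaker inhibition and lower numbers for stronger inhibition), compound 2 has the lower of the two numbers, at 1.61 ug/mL, which makes it the stronger inhibitor of this pair. The next compound, compound 3 `CC(=O)N1N=C(c2ccc3ccccc3c2)OC1c1ccccc1O`, keeps the shared core and changes one group: 2-hydroxyphenyl in place of 3-fluorophenyl on a saturated ring carbon. Put simply, 2-hydroxyphenyl stands in place of 3-fluorophenyl on a saturated ring carbon.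

For the measured compounds named here, only one measured step bears on this change: a 4.3-fold lower number from compound 1 to compound 2 (0.64 log units; beyond the scatter). It is modest but beyond the scatter, and it involves a swap on that same carbon. Compound 3 carries 2-hydroxyphenyl where compound 1 carries 2-bromophenyl, so compound 3 may move back toward compound 1 at 6.98 ug/mL. Going by the values given here, a single pair cannot prove this, and no hydroxyl-bearing compound has been measured yet. A modest rise in this assay is therefore expected, meaning weaker inhibition. The expected step is a 2.5-fold higher number from compound 2 to compound 3 (0.40 log units; beyond the scatter). Compound 3 is estimated at 4 ug/mL, with an expected range from 1.3 ug/mL to 12 ug/mL.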

Compound 3, half-maximal inhibitory concentration: 2.58 ug/mL
Compound 3: middle estimate off by 1.6-fold (0.19 log units), on the high side, within the range that was stated.
By their numbers in this assay, from the lowest: compounds 2 and 3 (each within the scatter of the next); then compound 1.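

In this assay, putting 2-hydroxyphenyl in place of 3-fluorophenyl on the saturated ring carbon gives a 1.6-fold higher number from compound 2 to compound 3 (0.20 log units; within the scatter) and so leaves the two compounds indistinguishable, even though the entering group has a hydrogen-bond donor and a hydrogen-bond acceptor and the leaving group has neither. The new comparison on an aromatic carbon, hydroxy in place of bromo, gives a 2.7-fold lower number from compound 1 to compound 3 (0.43 log units; beyond the scatter) in a step that is modest but real, and it leaves compound 1 as the weakest inhibitor of the three. The earlier drop from compound 1 to compound 2 therefore need not depend on fluorine or on 3-fluorophenyl specifically, since compound 3 also has a lower number than compound 1 while carrying a different group.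

Nothing available here explains why these groups give these numbers. From the compounds shown here alone, it remains open how this carbon would respond to a phenyl ring bearing an amine, a carboxylic acid or a methoxy group, or to a plain unsubstituted phenyl ring, and these could show whether the tolerance seen with compound 2 and compound 3 extends further.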